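Cyclohexyl to Phenyl on the Side-Chain Ester of a Glycoside

A few compounds are considered here, and "the series" means these few. Any claim that something is new, unique, unknown or untested is made for them only; others in the source may bear on it.

The set consists of four closely related glycosides measured, or to be measured, in a functional assay on HeLa cells (Homo sapiens) for antiproliferative activity, read by MTT assay, with a stated time of 72 h; a higher number here means a weaker inhibitor, a lower number a stronger inhibitor. Compound 1, `C/C=C1/[C@H](O[C@@H]2O[C@H](COC(C)=O)[C@@H](OC(C)=O)[C@H](OC(C)=O)[C@H]2OC(C)=O)OC=C(C(=O)OC)[C@H]1CC(=O)OCCCCCCCCCCCCCCC`, gives 17000 nM. Compound 2, `C/C=C1/[C@H](O[C@@H]2O[C@H](CO)[C@@H](O)[C@H](O)[C@H]2O)OC=C(C(=O)OC)[C@H]1CC(=O)OCCC1CCCCC1`, gives 5600 nM, which is the lowest of the two numbers recorded, and the gap from compound 1 to compound 2 lies beyond the usual scatter of the assay. Compound 3, `C/C=C1/[C@H](O[C@@H]2O[C@H](CO)[C@@H](O)[C@H](O)[C@H]2O)OC=C(C(=O)O)[C@H]1CC(=O)O`, shows only a limit of the assay, > 50000 nM, and no number; this is the limit described as the limit of > 50000 nM in this assay, at which 1 of the 3 values shown sits.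

The unmeasured member is compound 4, `C/C=C1/[C@H](O[C@@H]2O[C@H](CO)[C@@H](O)[C@H](O)[C@H]2O)OC=C(C(=O)OC)[C@H]1CC(=O)OCCc1ccccc1`. It differs from compound 2 in one place: phenyl in place of cyclohexyl on a saturated chain carbon, two bonds along the chain from an oxygen next to a carbonyl group. The sugar, the core and the rest of the chain are shared between compound 2 and compound 4.

Among the measured compounds shown here, because no measured pair in this set differs by exactly this kind of change, the direction of the step cannot be read off from the data, and a step of modest size is expected, likely no further than the edge of the scatter. The estimate for compound 4 in this assay is 7000 nM, with a range from 3000 nM to 17000 nM, which means an expected step of a 1.3-fold higher number from compound 2 to compound 4 (0.10 log units; within the scatter).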

Compound 4, half-maximal inhibitory concentration: 18500 nM
Compound 4: the middle estimate sits 2.6-fold (0.42 log units) below what was measured, outside the stated range (above it).
By their numbers in this assay, from the lowest: compound 2; then compounds 1 and 4 (each within the scatter of the next). At a limit, above all of these: compound 3.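

In this assay the ring carried by the side-chain ester proves not to be interchangeable: phenyl in place of cyclohexyl, on a saturated chain carbon, two bonds along the chain from an oxygen next to a carbonyl group, gives a 3.3-fold higher number from compound 2 to compound 4 (0.52 log units; beyond the scatter). Among the compounds shown here, this is the first step in the set that can be read for a single change, and since the sugar, the core and the rest of the chain are shared, all of it belongs to the exchange of a non-aromatic ring for an aromatic ring of six carbons. At this position the cyclohexyl compound is therefore the stronger of the pair by a margin beyond the scatter, although nothing measured here says why the two rings differ.

As far as these compounds go, it remains open how other groups would fare at the same place, such as a cyclopentyl ring, a pyridyl ring or an open hexyl chain, or a longer chain leading to the ring. From the compounds shown here alone, it is also open whether the step would keep its size on a sugar carrying acetyl groups, as in compound 1, or with a carboxylic acid in the core, as in compound 3.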